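This account rests on a few compounds, and the source may have more. Where it says the series, first, only, none or still open, it means among the compounds named here.

Measured in an ADME assay on HT-29 cells (Homo sapiens) for cytotoxicity, read by MTT assay, with a stated time of 72 h; a lower number here means a stronger inhibitor, a higher number a weaker inhibitor:
Compound 1 `COc1ccc(C2=C(c3cc(OC)c(OC)c(OC)c3)C(=O)C(OC(C)=O)C2)cc1OC(C)C`: > 100 ug/mL, a limit of the assay
Compound 2 `COc1ccc(C2=C(c3cc(OC)c(OC)c(OC)c3)C(=O)C(O[SiH2]C(C)(C)C)C2)cc1`: 5 ug/mL
Compound 3 `COc1ccc(C2=C(c3cc(OC)c(OC)c(OC)c3)C(=O)C(O[SiH2]C(C)(C)C)C2)cc1OC(C)C`: 9 ug/mL

Among the numbers, the nearest neighbour of compound 3 is compound 2, and the two lie within the scatter of each other. Compound 4 `COc1cc(C2=C(c3ccc(SC)cc3)CC(O[SiH2]C(C)(C)C)C2=O)cc(OC)c1OC` differs from compound 3 in one place: 4-(methylsulfanyl)phenyl in place of 3-isopropoxy-4-methoxyphenyl on a double-bonded ring carbon. The large step of an at least 11-fold lower number from compound 1 to compound 3 (1.04 log units; beyond the scatter) concerns the oxygen on a saturated carbon, which this change leaves alone. Only a 1.8-fold higher number from compound 2 to compound 3 (0.26 log units; within the scatter) touches the aromatic group, so no step beyond the scatter is expected in this assay. The estimate means a 1.5-fold lower number from compound 3 to compound 4 (0.18 log units; within the scatter), an expected step. For compound 4 the expected value is 6 ug/mL, with an estimated range of 2 ug/mL to 20 ug/mL.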

Compound 4, half-maximal inhibitory concentration: < 1 ug/mL
Compound 4 gave a limit, no number; the forecaster's own chance of this, stated with the estimate: 5%; middle value at least 6.0-fold (0.77 log units) away from the limit.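

In this assay compound 4 stands at a limit and not at a number: the limit of < 1 ug/mL in this assay, at which 1 of the 4 values shown sits. Within the data shown here, the aromatic group on the double-bonded ring carbon had so far moved the number only within the scatter, yet 4-(methylsulfanyl)phenyl in place of 3-isopropoxy-4-methoxyphenyl gives an at least 9.0-fold lower number from compound 3 to compound 4 (0.95 log units; beyond the scatter). Methylsulfanyl in place of methoxy on an aromatic carbon, on its own, gives an at least 5.0-fold lower number from compound 2 to compound 4 (0.69 log units; beyond the scatter), so this single swap is enough for a step beyond the scatter.

The compounds shown leave open the true value of compound 4, and how an ethylsulfanyl or a dimethylamino group in place of methylsulfanyl would read.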